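Swapping the anilide substituent in the bis-benzylidene piperidinone series

The source may hold more compounds than are shown below. What is called first, only, known or untested is meant among the compounds shown, and "the series" means these compounds.

Of the compounds shown here, three sharing the same core have been measured in a functional assay on CCRF-CEM cells (Homo sapiens) for cytotoxicity; a higher number here means a weaker inhibitor, a lower number a stronger inhibitor. Compound 1 `COc1ccc(NC(=O)/C=C/C(=O)N2C/C(=C\c3ccc([N+](=O)[O-])cc3)C(=O)/C(=C/c3ccc([N+](=O)[O-])cc3)C2)cc1` gives 760 nM. Compound 2 `O=C(/C=C/C(=O)N1C/C(=C\c2ccccc2)C(=O)/C(=C/c2ccccc2)C1)Nc1ccc([N+](=O)[O-])cc1` gives 40000 nM. Compound 3 `CC(=O)c1ccc(NC(=O)/C=C/C(=O)N2C/C(=C\c3ccccc3)C(=O)/C(=C/c3ccccc3)C2)cc1` gives 1700 nM, which places compound 3 second highest of the three numbers, nearest to compound 1 and furthest from compound 2. Among the measured compounds shown here, the one single-point step among the measured compounds, a 24-fold lower number from compound 2 to compound 3 (1.37 log units; beyond the scatter), shows that the group on the anilide ring can move the number a long way.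

Compound 4 `Cc1ccc(NC(=O)/C=C/C(=O)N2C/C(=C\c3ccccc3)C(=O)/C(=C/c3ccccc3)C2)cc1C` differs from compound 3 by 3,4-dimethylphenyl in place of 4-acetylphenyl on an amide-type nitrogen. For the measured compounds named here, no measured step covers this exact exchange, so the step from compound 2 to compound 3 is the only guide, and it only shows that this position is sensitive. Because of a 24-fold lower number from compound 2 to compound 3 (1.37 log units; beyond the scatter) a step of either direction is possible, and a modest rise is expected as the central estimate. Compound 4 is therefore expected at 3500 nM, within 700 nM to 18000 nM, a step of a 2.1-fold higher number from compound 3 to compound 4 (0.31 log units; beyond the scatter).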

Compound 4, half-maximal inhibitory concentration: 7100 nM
The estimate for compound 4 lay 2.0-fold (0.31 log units) below the measured number, and the stated range covers the measured number.
By their numbers in this assay, from the lowest: compound 1; then compound 3; then compound 4; then compound 2.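

In this assay the exchange of 4-acetylphenyl for 3,4-dimethylphenyl on the amide-type nitrogen gives a 4.2-fold higher number from compound 3 to compound 4 (0.62 log units; beyond the scatter) and so costs part of what the acetyl-bearing anilide had gained. Against 4-nitrophenyl the same group gives a 5.6-fold lower number from compound 2 to compound 4 (0.75 log units; beyond the scatter) as its step, which places compound 4 between compound 3 and compound 2 and shows that this position grades its groups rather than merely separating two extremes. No measurement of any property of these groups is at hand to explain that order.

The compounds shown leave open where an amine or a carboxylic acid on the anilide ring would fall within this span. They also leave open whether a single methyl would behave as the two methyl groups of compound 4 do.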